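Chloro to Nitro on the Phenyl of Compound 1

A few compounds are considered here, and "the series" means these few. Any claim that something is new, unique, unknown or untested is made for them only; others in the source may bear on it.

The measured compounds:
- compound 1, `CC(=O)N1N=C(c2ccc(-n3c(C)ccc3C)cc2)OC1c1ccccc1Cl`, 206000 nM
- compound 2, `O=C(NNC(=O)c1ccccc1[N+](=O)[O-])c1ccc(-n2cccc2)cc1`, 205000 nM
- compound 3, `Cc1ccc(C)n1-c1ccc(-c2n[nH]c(=S)n2N)cc1`, 170000 nM

In an ADME assay on A549 cells (Homo sapiens) for cytotoxicity, read by MTT assay, with a stated time of 72 h (a lower number here means a stronger inhibitor, a higher number a weaker inhibitor), compound 1 gives 206000 nM. Its nearest neighbour on this scale is compound 2 with 205000 nM, and compound 3 with 170000 nM is the one furthest from it; both gaps lie within the scatter, so compound 1 cannot be told apart from either of them on these numbers. All three sit in a range where the cells tolerate the compounds well.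

Compound 4, `CC(=O)N1N=C(c2ccc(-n3c(C)ccc3C)cc2)OC1c1ccccc1[N+](=O)[O-]`, has not yet been measured in this assay. It differs from compound 1 in one place: nitro in place of chloro on an aromatic carbon. For the measured compounds named here, no comparable pair of measured compounds shows what such a swap does here, and the three measured values themselves spread no further than the scatter. The expectation for the step from compound 1 to compound 4 is therefore a 1.0-fold lower number from compound 1 to compound 4 (0.01 log units; within the scatter), a move in no particular direction and not beyond the scatter. Compound 4 is accordingly estimated at 200000 nM, with a likely range from 100000 nM to 400000 nM.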

Compound 4, half-maximal inhibitory concentration: 182000 nM
Beside the measured number, compound 4's estimate is 1.1-fold (0.04 log units) above it; measured number inside the range.
By their numbers in this assay, from the lowest: compounds 3, 4, 2 and 1 (each within the scatter of the next).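

For the compounds shown here, the swap of 2-chlorophenyl to 2-nitrophenyl gives the first one-place comparison in this assay, and it reads as a 1.1-fold lower number from compound 1 to compound 4 (0.05 log units; within the scatter). On this aromatic carbon, ortho to a large group, the single chlorine atom can thus give way to the three heavy atoms of nitro, with its two hydrogen-bond acceptors, without a shift that can be told from the scatter. No available evidence explains this outcome.

As far as these compounds go, whether an amine or a carboxylic acid on this same carbon would move the number beyond the scatter remains open. So does whether nitro in place of chloro would give a similarly small step elsewhere on the ring or on a different core.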